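This account rests on a few compounds, and the source may have more. Where it says the series, first, only, none or still open, it means among the compounds named here.

Measured so far:
compound 1 `O=C1/C(=C\c2ccccc2[N+](=O)[O-])c2ccccc2N1c1c(Cl)cccc1Cl`: 10 ug/mL
compound 2 `O=C1/C(=C\c2cccc(Cl)c2)c2ccccc2N1c1c(Cl)cccc1Cl`: 16 ug/mL

Two compounds of the series have been run in a functional assay on L132 cells (Homo sapiens) for cytotoxicity, read by MTT assay, with a stated time of 72 h; a higher number here means that more compound is needed for the effect, a lower number that less compound is needed. Compound 1 gives 10 ug/mL and compound 2 gives 16 ug/mL. Compound 2 holds the higher of the two numbers; its nearest neighbour is compound 1, and the gap between them is a 1.6-fold higher number from compound 1 to compound 2 (0.20 log units; within the scatter), which stays within the scatter of this assay. No ordering of the two can be read from that.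

Compound 3 `O=C1/C(=C\c2ccc(Cl)cc2)c2ccccc2N1c1c(Cl)cccc1Cl` is not yet measured. Its difference from compound 2 is 4-chlorophenyl in place of 3-chlorophenyl on a double-bonded chain carbon bound to a double-bonded ring carbon: the same atoms, joined differently, with the chlorine moved on the phenyl that hangs from the double-bonded chain carbon.

Within the data shown here, the only step available for comparison is the one from compound 1 to compound 2, which swapped the whole aryl group at that place and still fell within the scatter. Among the measured compounds shown here, no measured step moves a chlorine around the phenyl. On that basis the step from compound 2 to compound 3 in this assay is expected to be small, with no direction favoured: a 1.1-fold lower number from compound 2 to compound 3 (0.06 log units; within the scatter). Compound 3 is therefore estimated at 14 ug/mL, in the range 7 ug/mL to 30 ug/mL.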

Compound 3, concentration for half-maximal effect: 9 ug/mL
Estimate against measurement, compound 3: 1.6-fold (0.19 log units) above; measured number inside the range.
By their numbers in this assay, from the lowest: compounds 3, 1 and 2 (each within the scatter of the next).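

In this assay, moving the chlorine around the phenyl on a double-bonded chain carbon bound to a double-bonded ring carbon gives a 1.8-fold lower number from compound 2 to compound 3 (0.25 log units; within the scatter) and is the only step shown that changes the chlorine's place while keeping the same atoms. Exchanging 2-nitrophenyl for 4-chlorophenyl at the same place gives a 1.1-fold lower number from compound 1 to compound 3 (0.05 log units; within the scatter) and so adds a second whole-group exchange that stays within the scatter, which means that 2-nitrophenyl, 3-chlorophenyl and 4-chlorophenyl cannot be put in any order at this place in this assay. No measurement is available that could explain these values or the absence of a readable separation among them.

Still open, on these data alone, is whether a different kind of group at this place, such as an amine, a carboxylic acid or a longer chain in place of the aryl group, would move the number beyond the scatter. Also open, as far as these compounds go, are the result with 2-chlorophenyl, which would complete the set of chlorine placements, and the effect of any change elsewhere on the shared core.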